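This account rests on a few compounds, and the source may have more. Where it says the series, first, only, none or still open, it means among the compounds named here.

So far, three compounds have been measured in a functional assay on HCT-116 cells (Homo sapiens) for cytotoxicity, read by hypoxanthine incorporation, with a stated time of 72 h, tested at 10 uM (on this read-out lower numbers stand for less inhibition of growth and higher numbers for more inhibition of growth at the one concentration tested), and they fall into two clearly separated levels. Compound 1 `CC(C)[C@H]1NC(=O)[C@@H](Cc2ccccc2)N(C)C(=O)[C@H](Cc2ccccc2)NC(=O)[C@H](COCc2ccccc2)NC(=O)[C@H](CC2CCCCC2)NC1=O` gives 93% and compound 2 `CC(C)[C@H]1NC(=O)[C@@H](Cc2ccccc2)N(C)C(=O)[C@H](Cc2ccccc2)NC(=O)[C@H](CO)NC(=O)[C@H](CC2CCCCC2)NC1=O` gives 18% in this test. Compound 3 `CC(C)C[C@H]1C(=O)N[C@@H](CCCCNC(=O)OCc2ccccc2)C(=O)N[C@@H](Cc2ccccc2)C(=O)N(C)[C@H](Cc2ccccc2)C(=O)N[C@@H](C(C)C)C(=O)N1C` gives 99% in this assay and so stands within the scatter of compound 1 and far beyond the scatter from compound 2.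

Compound 4 `CC(C)C[C@H]1C(=O)N[C@@H](CCCCNC(=O)OC(C)(C)C)C(=O)N[C@@H](Cc2ccccc2)C(=O)N(C)[C@H](Cc2ccccc2)C(=O)N[C@@H](C(C)C)C(=O)N1C` has not yet been measured. It departs from compound 3 at a single place, with tert-butyl in place of benzyl on an oxygen next to a carbonyl group.

Among the measured compounds shown here, only one measured step bears on this change, and only loosely. Hydrogen in place of benzyl on an oxygen on a saturated carbon gave a large step, a number 75 percentage points lower from compound 1 to compound 2 (beyond the scatter) in this assay. That step shows that losing a benzyl can matter in this set, but it involves a different oxygen, and hydrogen rather than tert-butyl takes the place of the benzyl. For the measured compounds named here, a much smaller fall is therefore expected here, and no measured pair tests this exchange directly. The expected step is a number 17 percentage points lower from compound 3 to compound 4 (beyond the scatter) by this estimate. Compound 4 is estimated at 82% with an expected range from 50% to 100% in this assay.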

Compound 4, percent growth inhibition at one concentration: 36%
The estimate for compound 4 lay 46 percentage points above the measured number; measured number below the stated range.
By their numbers in this assay, from the lowest: compound 2; then compound 4; then compounds 1 and 3 (each within the scatter of the next).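

In this assay, tert-butyl in place of benzyl on an oxygen next to a carbonyl group gives a number 63 percentage points lower from compound 3 to compound 4 (beyond the scatter), so this end of the side chain is not a place where the two groups can be exchanged freely. The change is confined to a carbon-only group: the six-membered aromatic ring leaves and the group shrinks from 7 heavy atoms to 4, while the counts of hydrogen-bond donors and acceptors and the net charge stay the same, which shows that a large fall can occur without any change in those counts. With a number 75 percentage points lower from compound 1 to compound 2 (beyond the scatter), this makes two single-place changes among the compounds shown in which losing a benzyl goes with a large fall, and no measurement shown accounts for either step.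

This one exchange removes the aromatic ring and changes the size and shape of the group together, so the pair cannot say which of these matters. On these data alone, how a phenethyl or methyl group on that oxygen, or a free amine in place of the (benzyloxycarbonyl)amino group, would fare remains open.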